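Changing the Aryl Group on a Sulfonamide Nitrogen

A few compounds are considered here, and "the series" means these few. Any claim that something is new, unique, unknown or untested is made for them only; others in the source may bear on it.

Three sulfonamides sharing one core have been measured in a functional assay on J774 cells (Mus musculus) for cytotoxicity; a lower number here means a stronger inhibitor, a higher number a weaker inhibitor. Compound 1 `CCCN(CCC)c1c([N+](=O)[O-])cc(S(=O)(=O)Nc2ccc(OC)cc2)cc1[N+](=O)[O-]` gives 15000 nM, compound 2 `CCCN(CCC)c1c([N+](=O)[O-])cc(S(=O)(=O)Nc2ccc(C)cc2)cc1[N+](=O)[O-]` gives 11000 nM, and compound 3 `CCCN(CCC)c1c([N+](=O)[O-])cc(S(=O)(=O)Nc2cccc(C)c2)cc1[N+](=O)[O-]` gives 16000 nM. Compound 3 cannot be told apart from the other two, since a 1.1-fold higher number from compound 1 to compound 3 (0.03 log units; within the scatter) and a 1.5-fold higher number from compound 2 to compound 3 (0.16 log units; within the scatter) both lie within the usual scatter of repeated measurements.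

The next compound is compound 4 `CCCN(CCC)c1c([N+](=O)[O-])cc(S(=O)(=O)Nc2ccc(Cl)c(Cl)c2)cc1[N+](=O)[O-]`, which has 3,4-dichlorophenyl in place of 3-methylphenyl on a sulfonamide nitrogen. The remaining measured step, a 1.4-fold lower number from compound 1 to compound 2 (0.13 log units; within the scatter), also lies within the scatter, so none of the changes made so far has moved the number measurably in this assay. Within the data shown here, none of the measured compounds carries chlorine, however, so this evidence is only indirect. No shift beyond the scatter is therefore expected, and the estimate is a 1.3-fold lower number from compound 3 to compound 4 (0.12 log units; within the scatter). For compound 4 the expected value is 12000 nM, with an estimated range from 5000 nM to 28000 nM.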

Compound 4, half-maximal inhibitory concentration: 7200 nM
Compound 4: the middle estimate sits 1.7-fold (0.22 log units) above what was measured, within the range that was stated.
By their numbers in this assay, from the lowest: compounds 4, 2, 1 and 3 (each within the scatter of the next, the first and the last beyond it).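

Unlike the steps among compound 1, compound 2 and compound 3, which all stayed within the scatter, changing the aryl group on the sulfonamide nitrogen to 3,4-dichlorophenyl gives steps that exceed it in this assay (a 2.2-fold lower number from compound 3 to compound 4 (0.35 log units; beyond the scatter) and a 2.1-fold lower number from compound 1 to compound 4 (0.32 log units; beyond the scatter)), though both are modest. The third comparison (a 1.5-fold lower number from compound 2 to compound 4 (0.18 log units; within the scatter)) stays within the scatter, so compound 4 cannot be told apart from compound 2, and this position has shown only a small range so far. Nothing available explains these steps.

From the compounds shown here alone, it remains open whether a phenyl group carrying a single chlorine would give the same steps as the 3,4-dichlorophenyl group. Also open, going by these compounds, is what a carboxylic acid or an amine on this aryl group would do to the number.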